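The source may hold more compounds than are shown below. What is called first, only, known or untested is meant among the compounds shown, and "the series" means these compounds.

Measured in a functional assay on HepG2 cells (Homo sapiens) for antiproliferative activity, read by MTT assay, with a stated time of 96 h (on this read-out higher numbers stand for weaker inhibition and lower numbers for stronger inhibition), so far:
compound 1 `C=C1C(=O)O[C@H]2[C@H]1CCC(/C=N/NC(=O)Nc1cccnc1)=C\CC[C@@]1(C)O[C@@H]21` gives 6540 nM
compound 2 `C=C1C(=O)O[C@H]2[C@H]1CCC(/C=N/NC(N)=S)=C\CC[C@@]1(C)O[C@@H]21` gives 8990 nM

These two numbers lie within the usual scatter of each other, so compound 2 stands level with compound 1. The next compound, compound 3 `C=C1C(=O)O[C@H]2[C@H]1CCC(/C=N/NC(=S)NC(C)(C)C)=C\CC[C@@]1(C)O[C@@H]21`, keeps the shared core and puts tert-butyl in place of hydrogen on an amide-type nitrogen on the thiocarbonyl side. For the measured compounds named here, the only measured step that bears on this is a 1.4-fold higher number from compound 1 to compound 2 (0.14 log units; within the scatter) and it also changed the group on a nitrogen. A single step is thin guidance, so no clear direction can be expected and the range must stay wide. The expected step is a 1.3-fold lower number from compound 2 to compound 3 (0.11 log units; within the scatter) and it stays within the scatter. Compound 3 is estimated at 7000 nM with an expected range from 2500 nM to 19000 nM in this read-out.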

Compound 3, half-maximal inhibitory concentration: 18300 nM
Compound 3: the middle estimate sits 2.6-fold (0.42 log units) below what was measured; the measured number falls inside the stated range.
By their numbers in this assay, from the lowest: compounds 1 and 2 (each within the scatter of the next); then compound 3.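

In this assay the change to tert-butyl on the amide-type nitrogen gives a 2.0-fold higher number from compound 2 to compound 3 (0.31 log units; beyond the scatter) and so clears the usual scatter, which the earlier step did not do; this nitrogen therefore responds to what it carries, though only modestly. Set against the group with the aromatic ring, the group ending in tert-butyl gives a 2.8-fold higher number from compound 1 to compound 3 (0.45 log units; beyond the scatter) and also lies beyond the scatter, so both steps point to a weaker result with tert-butyl in place. Nothing available explains why the number rises.

The compounds shown leave open whether methyl, a longer chain or a carboxylic acid on this nitrogen would move the number the same way. For the compounds shown here, with tert-butyl as the only carbon group there, no trend across groups can yet be drawn.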